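A few compounds are considered here, and "the series" means these few. Any claim that something is new, unique, unknown or untested is made for them only; others in the source may bear on it.

Three measured compounds share one core and differ at two places: the side chain on the carbon that carries the amide-bearing phenyl ring, and the aromatic ring on the carbon with a double bond to nitrogen. Compound 1 `CC(C)[C@H](c1ccc(C(=O)NCc2nn[nH]n2)cc1)N1C(=O)C(c2cc(Cl)cc(Cl)c2)=N[C@]12CC[C@@H](C(C)(C)C)CC2` gives 2200 nM in a functional assay on CHO cells for antagonist activity at Glucagon receptor (Homo sapiens), read by cAMP accumulation, with stated times of 30 min and 45 min; a lower number here means a stronger inhibitor, a higher number a weaker inhibitor. Compound 2 `C[C@H](c1ccc(C(=O)NCCC(=O)O)cc1)N1C(=O)C(c2cccc(Cl)c2)=N[C@]12CC[C@@H](C(C)(C)C)CC2` gives 480 nM in this assay. Compound 3 `CC(C)(C)CC[C@H](c1ccc(C(=O)NCc2nn[nH]n2)cc1)N1C(=O)C(c2cncc(Cl)c2)=N[C@]12CC[C@@H](C(C)(C)C)CC2` gives 480 nM in this assay, level with compound 2 at the digits shown, so the two together hold the lowest numbers of the three, while compound 1 returns a higher number.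

Compound 4 `CC(C)(C)CC[C@H](c1ccc(C(=O)NCc2nn[nH]n2)cc1)N1C(=O)C(c2cccc(C(F)(F)F)c2)=N[C@]12CC[C@@H](C(C)(C)C)CC2` keeps everything of compound 3 except one ring: 3-(trifluoromethyl)phenyl in place of 5-chloropyridin-3-yl on a carbon with a double bond to nitrogen. Within the data shown here, no measured pair isolates exactly this exchange, so the outcome is uncertain. The three measured compounds show that chlorinated phenyl and chlorinated pyridinyl rings at this carbon both give numbers in the same broad region, which suggests that the step is expected to be modest in this assay, either direction, and likely within the scatter, as a 1.3-fold higher number from compound 3 to compound 4 (0.10 log units; within the scatter). Compound 4 is therefore estimated at 600 nM, within a range from 200 nM to 2000 nM.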

Compound 4, half-maximal inhibitory concentration: 180 nM
Estimate against measurement, compound 4: 3.3-fold (0.52 log units) above; the whole stated range lies above it.
By their numbers in this assay, from the lowest: compound 4; then compounds 2 and 3 (each within the scatter of the next); then compound 1.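

In this assay, this ring is a place where the choice of group can be read in the number. Among these compounds, with the rest of compound 3 held fixed, putting 3-(trifluoromethyl)phenyl in place of 5-chloropyridin-3-yl gives a 2.7-fold lower number from compound 3 to compound 4 (0.43 log units; beyond the scatter) and so a real if modest gain, the first step here that changes one place only. No measured evidence says why the number falls at this position.

The exchange alters two things at once, swapping a ring nitrogen for carbon and chlorine for trifluoromethyl, so the compounds shown cannot say which of the two carries the step; a 3-chlorophenyl or a 5-(trifluoromethyl)pyridin-3-yl ring on the same scaffold would separate them. Also open, going by these compounds, is whether the same exchange gives a similar step with a shorter side chain, such as the isopropyl of compound 1.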